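Dipropylamino in place of diethylamino on compound 2

A few compounds are considered here, and "the series" means these few. Any claim that something is new, unique, unknown or untested is made for them only; others in the source may bear on it.

Measured in a functional assay on SK-BR-3 cells (Homo sapiens) for antiproliferative activity; on this read-out lower numbers stand for stronger inhibition and higher numbers for weaker inhibition:
compound 1 `CC(C)=CCc1cc(C(=O)Nc2cc3ccc(OCCC4CCCCN4)c(C)c3oc2=O)ccc1O`: 640 nM
compound 2 `CCN(CC)CCCOc1ccc2cc(NC(=O)c3ccc(O)c(CC=C(C)C)c3)c(=O)oc2c1C`: 4900 nM

Of the two measured compounds, compound 2 has the higher number, 4900 nM, and so the weaker inhibition. The next compound is compound 3 `CCCN(CCC)CCCOc1ccc2cc(NC(=O)c3ccc(O)c(CC=C(C)C)c3)c(=O)oc2c1C`, which carries dipropylamino in place of diethylamino on a saturated chain carbon, three bonds along the chain from an oxygen on an aromatic ring. Within the data shown here, the only measured step, a 7.7-fold higher number from compound 1 to compound 2 (0.88 log units; beyond the scatter), replaces piperidin-2-yl, a different change, and gives only a rough scale. Among the measured compounds shown here, no measured step covers this change alone. A small step toward a lower number in this assay is expected, possibly none beyond the scatter. The expected step is a 1.6-fold lower number from compound 2 to compound 3 (0.21 log units; within the scatter). For compound 3 the estimate is 3000 nM, with an expected range of 1100 nM to 8000 nM.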

Compound 3, half-maximal inhibitory concentration: > 50000 nM
Compound 3: no number, only a limit (the forecaster's own chance of this, stated with the estimate: 8%); middle value at least 16-fold (1.22 log units) from the limit.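

In this assay compound 3 gives only a limit, > 50000 nM, not a number: the limit of > 50000 nM in this assay, at which 1 of the 3 values shown sits. Dipropylamino in place of diethylamino at this position gives an at least 10-fold higher number from compound 2 to compound 3 (1.00 log units; beyond the scatter), so a change confined to the alkyl groups on the amine is enough to shift this read-out beyond the scatter. With piperidin-2-yl as the reference, (dipropylamino)methyl gives an at least 78-fold higher number from compound 1 to compound 3 (1.89 log units; beyond the scatter). On these data alone, the true size of both steps remains open. Also open, as far as these compounds go, is how dimethylamino, pyrrolidin-1-yl or morpholin-4-yl would read on the same chain.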